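A Methoxy Group in Place of Fluorine on the Styryl Ring

A few compounds are considered here, and "the series" means these few. Any claim that something is new, unique, unknown or untested is made for them only; others in the source may bear on it.

Compound 1 `C=C(C/C(=C\c1ccccc1)C(=O)c1ccccc1)C(=O)c1ccccc1` and compound 2 `C=C(C/C(=C\c1ccccc1F)C(=O)c1ccccc1)C(=O)c1ccccc1` share the same core and differ only in the ring on the double-bonded chain carbon. In a functional assay on WiDr cells (Homo sapiens) for inhibition, read by sulforhodamine B assay, with a stated time of 48 h (a higher number here means a weaker inhibitor of growth, a lower number a stronger inhibitor of growth), compound 1 gives 18000 nM, and compound 2 gives 17000 nM. The step of a 1.1-fold lower number from compound 1 to compound 2 (0.02 log units; within the scatter) is the only one measured so far, and it shows that placing a fluoro substituent on that ring left the number essentially where it was. Compound 2 thus stands at the lower of the two numbers, though its distance from compound 1 is within the scatter, so no order between the two can be claimed.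

Compound 3 `C=C(C/C(=C\c1ccc(OC)cc1)C(=O)c1ccccc1)C(=O)c1ccccc1` carries the change (4-methoxyphenyl in place of 2-fluorophenyl on a double-bonded chain carbon bound to a double-bonded chain carbon). For the measured compounds named here, no measured step covers a methoxy group on this ring; the one step that bears on substitution there, a 1.1-fold lower number from compound 1 to compound 2 (0.02 log units; within the scatter), was within the scatter. On that ground compound 3 is expected to show a step of a 1.1-fold lower number from compound 2 to compound 3 (0.05 log units; within the scatter), that is, no change beyond the scatter. Compound 3 is therefore estimated at 15000 nM in this assay, with a range from 6000 nM to 40000 nM.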

Compound 3, concentration for 50% growth inhibition: 470 nM
Compound 3: the middle estimate sits 32-fold (1.50 log units) above what was measured; measured number below the stated range.
By their numbers in this assay, from the lowest: compound 3; then compounds 2 and 1 (each within the scatter of the next).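

In this assay, the ring on the double-bonded chain carbon turns out to be far from indifferent to substitution: adding a methoxy group to that ring gives a 38-fold lower number from compound 1 to compound 3 (1.58 log units; beyond the scatter), and 4-methoxyphenyl in place of 2-fluorophenyl gives a 36-fold lower number from compound 2 to compound 3 (1.56 log units; beyond the scatter). The earlier pair had shown only a step within the scatter, so that result said something about a fluoro group alone and could not be carried over to substitution on this ring in general. The 4-methoxyphenyl group also counts a hydrogen-bond acceptor where the 2-fluorophenyl group counts none, but no measurement here connects that count, or anything else, to the size of the step.

The compounds shown leave open whether the large step belongs to the methoxy group itself or to where it sits on the ring, as the fluoro and methoxy groups are not compared at the same place. They also leave open whether a hydroxy group, an ethoxy group or an amine on this ring would give a number like that of compound 3.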